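From a Triazole Amide to a Carboxypropyl Chain

This account rests on a few compounds, and the source may have more. Where it says the series, first, only, none or still open, it means among the compounds named here.

Going by the values given here, compound 1 `O=C(Nc1nc[nH]n1)c1cc(=O)c2ccccc2o1` supplies the only number in this small set: in a functional assay on cells (Mast cell, Rattus norvegicus) for inhibition, with a stated time of 15 min (on this read-out higher numbers stand for an effect only at larger amounts of compound and lower numbers for an effect already at smaller amounts), compound 1 gives 5 ug/mL. Compound 2 `CN(C(=O)c1cc(=O)c2ccccc2o1)c1ccccc1` returned no result in this assay, recorded as "nd(insoluble)" (no result reported). Compound 3 `O=C(Nc1nnn[nH]1)c1cc2ccccc2c(=O)o1` reached only a limit of this assay, > 18 ug/mL. That limit marks the point at which one of the three shown values sits (the limit of > 18 ug/mL in this assay, at which 1 of the 3 values shown sits). Compound 4 `O=C(O)CCCNC(=O)c1cc(=O)c2ccccc2o1` has not yet been measured. It differs from compound 1 by 3-carboxypropyl in place of 1H-1,2,4-triazol-3-yl on an amide-type nitrogen. Among the compounds with values here, no step between measured compounds is available, so the size of this change is open. The account expects compound 4 to fall off somewhat in this assay, a step of a 3.0-fold higher number from compound 1 to compound 4 (0.48 log units; beyond the scatter), larger than the usual scatter yet short of the limit. Compound 4 is estimated at 15 ug/mL, within 4 ug/mL to 60 ug/mL.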

Compound 4, concentration for half-maximal effect: > 18 ug/mL
Compound 4: no number, only a limit (the forecaster's own chance of this, stated with the estimate: 40%); at least 1.2-fold (0.07 log units) between middle value and limit.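

Going by these compounds alone, this gives the first readable step at this position: on the amide-type nitrogen, 3-carboxypropyl in place of 1H-1,2,4-triazol-3-yl brings an at least 3.6-fold higher number from compound 1 to compound 4 (0.55 log units; beyond the scatter) in this assay. On this read-out, the 3-carboxypropyl chain does not retain the effect seen with the triazolyl group of compound 1. The step gives only a minimum size, since compound 4 reaches a limit and not a number: the limit of > 18 ug/mL in this assay, at which 2 of the 4 values shown sit.

From the compounds shown here alone, how far compound 4 lies beyond that limit remains open. So does whether a shorter chain ending in a carboxylic acid, or an amine in place of that acid, would restore the effect.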